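This account rests on a few compounds, and the source may have more. Where it says the series, first, only, none or still open, it means among the compounds named here.

Values measured so far in a functional assay on Gurav cells (Homo sapiens) for inhibition, read by sulforhodamine B assay (a higher number here means a weaker inhibitor of growth, a lower number a stronger inhibitor of growth), are these.

Compound 1 `c1ccc(-c2ccc(-c3ccc(-c4nc5ccccc5[nH]4)cc3)cc2)cc1` gives 100000 nM
Compound 2 `FC(F)(F)c1ccc(-c2ccc(-c3ccc(-c4nc5ccccc5[nH]4)cc3)cc2)cc1` gives 39100 nM
Compound 3 `FC(F)(F)Oc1ccc(-c2ccc(-c3ccc(-c4nc5ccccc5[nH]4)cc3)cc2)cc1` gives 100000 nM

Compound 3 stands level with compound 1 at the digits shown, and the two together hold the highest number of the three. Only compound 2 sits lower, as the step between them shows (a 2.6-fold higher number from compound 2 to compound 3 (0.41 log units; beyond the scatter)).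

The next compound, compound 4 `CN(C)c1ccc(-c2ccc(-c3ccc(-c4nc5ccccc5[nH]4)cc3)cc2)cc1`, carries dimethylamino in place of trifluoromethoxy on an aromatic carbon, para to a large group (dimethylamino in place of trifluoromethoxy on an aromatic carbon). Among the measured compounds shown here, no measured compound carries dimethylamino, so no step speaks for it directly. The nearest evidence is what happened when hydrogen on that aromatic carbon was replaced. Trifluoromethoxy left the number where it was (no change at the digits printed from compound 1 to compound 3 (within the scatter)), while trifluoromethyl moved it only modestly (a 2.6-fold lower number from compound 1 to compound 2 (0.41 log units; beyond the scatter)). Neither replacement produced a large change, so in this assay a large step is not expected here. A small move toward a lower number seems the likeliest outcome, and it may not clear the scatter. The estimated change is a 1.7-fold lower number from compound 3 to compound 4 (0.22 log units; within the scatter) on this evidence. Compound 4 is estimated at 60000 nM with 20000 nM to 100000 nM as the expected range.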

Compound 4, concentration for 50% growth inhibition: 100000 nM
Beside the measured number, compound 4's estimate is 1.7-fold (0.22 log units) below it, and the stated range covers the measured number.
By their numbers in this assay, from the lowest: compound 2; then compounds 1, 3 and 4 (each within the scatter of the next).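

In this assay, dimethylamino now joins trifluoromethoxy as a second group on this aromatic carbon, para to a large group, that leaves the number where hydrogen put it, with no change at the digits printed from compound 1 to compound 4 (within the scatter) and no change at the digits printed from compound 3 to compound 4 (within the scatter). Trifluoromethyl therefore remains the only one of the three replacements shown that separates from the others, as the exchange for dimethylamino gives a 2.6-fold higher number from compound 2 to compound 4 (0.41 log units; beyond the scatter), a modest step but one beyond the scatter; compounds 1, 3 and 4 share a single printed value and compound 2 is the lone exception. Nothing measured here accounts for this split among the groups.

The compounds shown leave open whether a different group on this same carbon, such as a nitrile, a carboxylic acid or a longer alkyl chain, would join compound 2 at a lower number or stay with the other three. They also leave open whether trifluoromethyl would give a step of similar size with a change elsewhere on the shared core, as every compound here differs only at this one place.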